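A Trifluoromethylcarbonyl Swap on the Ring Amine Nitrogen

The compounds below may be only part of what the source reports. "The series", "measured", "known", "first", "only" and "open" are said of these compounds alone.

Three measured compounds share one core: compound 1 `Cc1cc(C#N)cc(C)c1Oc1nc(Nc2ccc(C#N)cc2)ncc1/C=C/C(=O)NC1CC1`, compound 2 `C#CCNC(=O)/C=C/c1cnc(Nc2ccc(C#N)cc2)nc1Oc1c(C)cc(C#N)cc1C` and compound 3 `Cc1cc(C#N)cc(C)c1Oc1nc(Nc2ccc(C#N)cc2)ncc1/C=C/C(=O)N1CCN(S(=O)(=O)C(F)(F)F)CC1`. In an ADME assay on TZM cells (Homo sapiens) for cytotoxicity, with a stated time of 1 days (on this read-out higher numbers stand for lower toxicity in this test and lower numbers for higher toxicity in this test), compound 1 gives > 221 nM, which is a limit of the test rather than a number. Compound 2 gives > 222 nM in this assay, again only a limit. Compound 3 gives > 164 nM in this assay, also a limit. Among the measured compounds shown here, the single one-place step among them, a step that the two limits leave unreadable from compound 1 to compound 2, cannot be read in size because both ends are limits, as the limit of > 221 nM in this assay, at which 1 of the 3 values shown sits, and the limit of > 222 nM in this assay, at which 1 of the 3 values shown sits, show. For the measured compounds named here, compound 3 thus stands at a limit of its own, (the limit of > 164 nM in this assay, at which 1 of the 3 values shown sits), and every value in this set is a limit; no compound can be ranked against another.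

The new compound is compound 4 `Cc1cc(C#N)cc(C)c1Oc1nc(Nc2ccc(C#N)cc2)ncc1/C=C/C(=O)N1CCN(C(=O)C(F)(F)F)CC1`, and it differs from compound 3 by (trifluoromethyl)carbonyl in place of (trifluoromethyl)sulfonyl on an amine nitrogen in a ring. Going by the values given here, no measured step touches this position, and the one step that exists is unreadable, so there is nothing here that points to a change beyond the scatter. He expects the step that the limit leaves unreadable from compound 3 to compound 4 to stay within the scatter. Compound 4 is therefore estimated at 300 nM in this assay, in the range 150 nM to 2000 nM, most likely reported once more only as a limit.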

Compound 4, half-maximal cytotoxic concentration: > 174 nM
Compound 4 gave a limit, no number (the forecaster's own chance of this, stated with the estimate: 85%); the middle value does not contradict the limit.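

Compound 4, like compound 3, compound 1 and compound 2, is reported only as a limit, so none of the steps from compound 1, compound 2 or compound 3 to compound 4 can be read in size. The compounds shown leave open whether (trifluoromethyl)carbonyl and (trifluoromethyl)sulfonyl on an amine nitrogen in a ring differ at all in this assay.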